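A few compounds are considered here, and "the series" means these few. Any claim that something is new, unique, unknown or untested is made for them only; others in the source may bear on it.

Working notes on the series. Of the compounds shown here, two have numbers so far. Compound 1 `COc1cccc(CNC(=O)c2nn(-c3ccc(F)cc3)c(OC[C@@H](O)C[C@@H](O)CC(=O)O)c2C(C)C)c1` gives 16 nM in an assay on microsomes from liver for inhibition of 3-hydroxy-3-methylglutaryl-coenzyme A reductase (Rattus norvegicus); a higher number here means a weaker inhibitor, a lower number a stronger inhibitor. Compound 2 `COc1cc(CN(C)C(=O)c2nn(-c3ccc(F)cc3)c(OC[C@@H](O)C[C@@H](O)CC(=O)O)c2C(C)C)cc(OC)c1` gives 43 nM in this assay, the highest of the two numbers; its gap to compound 1 lies beyond the usual scatter, and since the two differ in more than one place nothing is drawn from that gap beyond what the two values themselves show.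

The next member is compound 3 `CC(C)c1c(C(=O)N(C)Cc2ccc(F)c(F)c2)nn(-c2ccc(F)cc2)c1OC[C@@H](O)C[C@@H](O)CC(=O)O`. Against compound 2 the change is 3,4-difluorophenyl in place of 3,5-dimethoxyphenyl on a saturated chain carbon bound to an amide-type nitrogen: both the methyl on the amide-type nitrogen and the rest of the shared core stay as they are. Within the data shown here, no pair of measured compounds isolates this swap, so the direction rests on no measured step. With 3,4-difluorophenyl in place of 3,5-dimethoxyphenyl a small movement is expected, on the order of the scatter or a little beyond it, leaning toward a lower number, and the expected step is a 1.4-fold lower number from compound 2 to compound 3 (0.16 log units; within the scatter). Compound 3 is accordingly estimated at 30 nM in this assay, with a range from 10 nM to 90 nM.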

Compound 3, half-maximal inhibitory concentration: 5.7 nM
The estimate for compound 3 lay 5.3-fold (0.72 log units) above the measured number, outside the stated range (below it).
By their numbers in this assay, from the lowest: compound 3; then compound 1; then compound 2.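

The step at this place, with the methyl on the amide-type nitrogen and the rest of the shared core held constant, shows that this assay responds clearly to the aryl group: 3,4-difluorophenyl in place of 3,5-dimethoxyphenyl on a saturated chain carbon bound to an amide-type nitrogen gives a 7.5-fold lower number from compound 2 to compound 3 (0.88 log units; beyond the scatter). The exchange of (3,4-difluorobenzyl)(methyl)amino for (3-methoxybenzyl)amino on a carbonyl carbon gives a 2.8-fold lower number from compound 1 to compound 3 (0.45 log units; beyond the scatter), so a methyl on the amide-type nitrogen does not by itself rule out a number lower than that of compound 1, although this step changes the methyl and the aryl group together and cannot assign the difference to either. No measurement at hand speaks to the reason for either step.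

The compounds shown leave open how much of the second step belongs to the methyl and how much to the fluorines, a split that a 3,4-difluorobenzyl group on the amide nitrogen without the methyl would address. Also open, as far as these compounds go, is how this place responds to a 3,4-dichlorophenyl group, or to a phenyl ring carrying a single fluorine or a nitrile.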